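A few compounds are considered here, and "the series" means these few. Any claim that something is new, unique, unknown or untested is made for them only; others in the source may bear on it.

Measured so far in an in vivo ADME assay on the whole organism (plasma, strain Sprague-Dawley) for pharmacokinetics, with Rattus norvegicus as the target, at a dose of 1 mg/kg by the intravenous route; on this read-out lower numbers stand for slow clearance and higher numbers for fast clearance
compound 1 `CCOC[C@H]1C[C@@](CC(C)C)(C(=O)O)N(C(=O)c2ccc(C(C)(C)C)c(OC)c2)[C@H]1c1nccs1` gives 5 mL/min/kg
compound 2 `COC[C@H]1C[C@@](CC(C)C)(C(=O)O)N(C(=O)c2ccc(C(C)(C)C)c(OC)c2)[C@H]1c1nccs1` gives 5 mL/min/kg

Within the data shown here, compound 2 gives 5 mL/min/kg in this assay and so stands level with compound 1, its only measured neighbour. Among the measured compounds shown here, compound 3 `COc1cc(C(=O)N2[C@@H](c3nccs3)[C@@H](CO)C[C@@]2(CC(C)C)C(=O)O)ccc1C(C)(C)C` has no measurement yet. Its difference from compound 2 is hydrogen in place of methyl on an oxygen on a saturated carbon and amounts to methoxymethyl to hydroxymethyl, with hydrogen in place of methyl on an oxygen on a saturated carbon.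

For the measured compounds named here, the one measured step that bears on this is no change at the digits printed from compound 1 to compound 2 (within the scatter) and it lies within the scatter. That step is a different change on the same chain, hydrogen in place of methyl on a saturated chain carbon bound to an oxygen on a saturated carbon. Going by the values given here, no measured compound carries the hydroxymethyl, so the guide is a loose one and the range is kept wide, more so on the upper side. The expected step is a 1.2-fold higher number from compound 2 to compound 3 (0.08 log units; within the scatter) and it is not expected to pass the scatter. In this assay compound 3 is estimated at 6 mL/min/kg with a range from 3 mL/min/kg to 14 mL/min/kg around that figure.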

Compound 3, clearance: 36 mL/min/kg
Compound 3: the middle estimate sits 6.0-fold (0.78 log units) below what was measured, and the stated range ends below it.
By their numbers in this assay, from the lowest: compounds 1 and 2 (each within the scatter of the next); then compound 3.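

In this assay the group on this oxygen can be shortened from ethyl to methyl with no change at the digits printed from compound 1 to compound 2 (within the scatter) as the result, but replacing methyl with hydrogen gives a 7.2-fold higher number from compound 2 to compound 3 (0.86 log units; beyond the scatter) at the same place. Replacing ethyl with hydrogen gives a 7.2-fold higher number from compound 1 to compound 3 (0.86 log units; beyond the scatter) as the matching result. Across these three compounds, the read-out therefore separates on whether the oxygen carries an alkyl group at all, not on which of the two alkyl groups it carries, so this position is not indifferent to every change on the chain. No measurement shown here accounts for the rise.

Still open, from the compounds shown here alone, is whether the rise belongs to the free hydroxy specifically or would also follow other replacements of the methoxy, such as a primary amine or a fluorine in place of the hydroxy in compound 3. Also open, going by these compounds, is whether a longer chain than ethyl on this oxygen, or a branched one such as isopropyl, would stay level with compound 1 and compound 2 or begin to move the read-out.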